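Diaryl pyrazole series: amide in place of carbamoyl

This account rests on a few compounds, and the source may have more. Where it says the series, first, only, none or still open, it means among the compounds named here.

Measured so far:
compound 1 `COc1cc(-c2nn(-c3cccc(NC(=O)Nc4ccc(Cl)c(Cl)c4)c3)cc2-c2ccncc2)ccc1Cl` 1470 nM
compound 2 `O=C(Nc1cccc(-n2cc(-c3ccncc3)c(-c3ccc(Cl)c(O)c3)n2)c1)Nc1ccc(Cl)c(Cl)c1` 1310 nM

Both numbers come from a functional assay on SN12C cells (Homo sapiens) for inhibition, read by sulforhodamine B assay, with a stated time of 48 h; on this read-out higher numbers stand for weaker inhibition of growth and lower numbers for stronger inhibition of growth. Going by the values given here, compound 1 holds the highest of the two numbers in this assay, and compound 2 sits nearest to it; the single measured step, a 1.1-fold lower number from compound 1 to compound 2 (0.05 log units; within the scatter), is within the scatter, so the two compounds cannot be ordered.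

Compound 3 `COc1cc(-c2nn(-c3cccc(NC(=O)c4ccccc4)c3)cc2-c2ccncc2)ccc1Cl` is not yet measured in this assay. It differs from compound 1 in one place: phenyl in place of (3,4-dichlorophenyl)amino on a carbonyl carbon. Among the compounds with values here, no measured step touches this part of the molecule; the only step known alters a different position and is itself within the scatter. There is therefore no measured basis for the size or direction of the change, and the expectation rests on the value of compound 1 alone, widened to allow a considerable move in either direction.

Compound 3 is expected to give 4000 nM, with a range of 1000 nM to 20000 nM. The expected step is a 2.7-fold higher number from compound 1 to compound 3 (0.43 log units; beyond the scatter), an estimate carrying wide uncertainty.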

Compound 3, concentration for 50% growth inhibition: 2950 nM
Estimate against measurement, compound 3: 1.4-fold (0.13 log units) above; measured number inside the range.
By their numbers in this assay, from the lowest: compounds 2, 1 and 3 (each within the scatter of the next, the first and the last beyond it).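

In this assay, going by these compounds alone, phenyl in place of (3,4-dichlorophenyl)amino on the carbonyl carbon gives a 2.0-fold higher number from compound 1 to compound 3 (0.30 log units; within the scatter), the only measured step at this position. This is a larger structural change than the step at the methyl on the oxygen, yet the two compounds still cannot be ordered: the growth-inhibition read-out does not separate the benzamido compound from the ((3,4-dichlorophenyl)carbamoyl)amino compound, even though the chlorines, the nitrogen and the hydrogen-bond donor of the leaving group are all absent from the entering phenyl. Nothing available on this pair bears on why the number stays within the scatter.

The exchange removes the nitrogen and the chlorines in a single step, so their separate contributions remain unresolved; an unsubstituted phenylamino group, or a 3,4-dichlorophenyl group placed directly on the carbonyl carbon, would pull them apart. Also open, as far as these compounds go, is how far this position tolerates groups of a different kind, such as a morpholine or a carboxylic acid on the phenyl ring, or a short alkyl chain in place of the ring.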